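Ring amine variation on the shared core: compound 4

The compounds below may be only part of what the source reports. "The series", "measured", "known", "first", "only" and "open" are said of these compounds alone.

Measured so far in a functional assay on CHO-K1 cells for antagonist activity at transient receptor potential cation channel subfamily V member 1 (Homo sapiens), read by FLIPR; on this read-out higher numbers stand for weaker inhibition and lower numbers for stronger inhibition:
compound 1 `CC(C(=O)NCc1ccc(C(F)(F)F)nc1N1CCCC1)c1ccc(NS(C)(=O)=O)c(F)c1` gives 0.6 nM;
compound 2 `C[C@H](C(=O)NCc1ccc(C(F)(F)F)nc1N1CC[C@H](N(C)C)C1)c1ccc(NS(C)(=O)=O)c(F)c1` gives 103 nM;
compound 3 `C[C@@H](C(=O)NCc1ccc(C(F)(F)F)nc1N1CCC(c2ccccc2)CC1)c1ccc(NS(C)(=O)=O)c(F)c1` gives 7.5 nM.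

Compound 1 stands at the lowest number of the three, with compound 3 the nearest and compound 2 the furthest, both gaps beyond the usual scatter. Compound 4 `CC(C(=O)NCc1ccc(C(F)(F)F)nc1N1CCN(C)CC1)c1ccc(NS(C)(=O)=O)c(F)c1` is not yet measured. It differs from compound 1 in one place: 4-methylpiperazin-1-yl in place of pyrrolidin-1-yl on an aromatic carbon. Going by the values given here, no step between measured compounds covers this exact change. The other member with a second nitrogen in the ring amine is compound 2, which gives 103 nM, so a step toward a higher number is expected in this assay, likely beyond the scatter. For compound 4 the estimate is 25 nM, range 4 nM to 150 nM, an expected step of a 42-fold higher number from compound 1 to compound 4 (1.62 log units; beyond the scatter).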

Compound 4, inhibition constant: 146 nM
Compound 4: the middle estimate sits 5.8-fold (0.77 log units) below what was measured; low and high end bracket the measured number.
By their numbers in this assay, from the lowest: compound 1; then compound 3; then compounds 2 and 4 (each within the scatter of the next).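

In this assay, going by these compounds alone, the ring amine at this place on the shared core is not freely exchangeable: 4-methylpiperazin-1-yl in place of pyrrolidin-1-yl gives a 240-fold higher number from compound 1 to compound 4 (2.39 log units; beyond the scatter), the only single-place step so far. No measurement at hand accounts for the size of this step.

Going by these compounds, the step changes ring size, the second ring nitrogen and the methyl group together, so their separate contributions remain open. Plain piperidin-1-yl, morpholin-4-yl and unmethylated piperazin-1-yl at this place would separate them.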